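Swapping the amine ring at the chain end of compound 3

This account rests on a few compounds, and the source may have more. Where it says the series, first, only, none or still open, it means among the compounds named here.

Compound 1 `COc1cc2c(Oc3ccc(NC(=O)c4nn(-c5ccccc5)c(=O)cc4C)cc3F)ccnc2cc1OCCCN1CCN(C)CC1` gives 2120 nM in a functional assay on U-87MG ATCC cells (Homo sapiens) for inhibition, read by MTT assay, with a stated time of 72 h; on this read-out higher numbers stand for weaker inhibition and lower numbers for stronger inhibition. Compound 2 `COc1cc2c(Oc3ccc(NC(=O)c4nn(-c5ccccc5C(F)(F)F)c(=O)cc4C)cc3F)ccnc2cc1OCCCN1CCCC1` gives 1010 nM. Compound 3 `COc1cc2c(Oc3ccc(NC(=O)c4nn(-c5ccccc5C(F)(F)F)c(=O)cc4C)cc3F)ccnc2cc1OCCCN1CCC(C)CC1` gives 1120 nM.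

Compound 3 stands second highest of the three numbers; its nearest neighbour is compound 2, and the change between them a 1.1-fold higher number from compound 2 to compound 3 (0.04 log units; within the scatter) is only a different amine ring at the end of the chain. Compound 4 `COc1cc2c(Oc3ccc(NC(=O)c4nn(-c5ccccc5C(F)(F)F)c(=O)cc4C)cc3F)ccnc2cc1OCCCN1CCN(C)CC1` carries the change (4-methylpiperazin-1-yl in place of 4-methylpiperidin-1-yl on a saturated chain carbon, three bonds along the chain from an oxygen on an aromatic ring). Among the measured compounds shown here, no measured step shows this exact swap, but the one measured change of the chain-end ring stayed within the scatter, and compound 1, which shares the chain end of compound 4, sits near the others. Compound 4 is therefore expected to change little, a 1.2-fold higher number from compound 3 to compound 4 (0.06 log units; within the scatter), and its value in this assay is estimated at 1300 nM, ranging from 600 nM to 3000 nM.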

Compound 4, half-maximal inhibitory concentration: 1170 nM
Estimate against measurement, compound 4: 1.1-fold (0.05 log units) above, within the range that was stated.
By their numbers in this assay, from the lowest: compounds 2, 3, 4 and 1 (each within the scatter of the next, the first and the last beyond it).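

Putting 4-methylpiperazin-1-yl in place of 4-methylpiperidin-1-yl at the chain end gives a 1.0-fold higher number from compound 3 to compound 4 (0.02 log units; within the scatter) in this assay and so adds a ring nitrogen without moving the reading beyond the scatter. Putting it in place of pyrrolidin-1-yl gives a 1.2-fold higher number from compound 2 to compound 4 (0.06 log units; within the scatter) and so all three amine rings read alike at this position when the trifluoromethyl group is present. With 4-methylpiperazin-1-yl held fixed, trifluoromethyl in place of hydrogen on an aromatic carbon gives a 1.8-fold lower number from compound 1 to compound 4 (0.26 log units; within the scatter) and that step also stays within the scatter.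

Still open, on these data alone, is whether a morpholine ring, a dimethylamino group or a longer chain would read differently. Nothing shown here offers a measured reason for these readings.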